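The source may hold more compounds than are shown below. What is called first, only, known or untested is meant among the compounds shown, and "the series" means these compounds.

Measured so far:
compound 1 `O=C1NCCN(c2cccc(F)c2)N1` — 19000 nM
compound 2 `O=C1NCCN(c2cccc(Cl)c2)N1` — 5300 nM
compound 3 `CC1CN(c2cccc(F)c2)NC(=O)N1` — 6300 nM

All three values come from an assay on RBL-1 cells for inhibition of Polyunsaturated fatty acid 5-lipoxygenase (Rattus norvegicus); a higher number here means a weaker inhibitor, a lower number a stronger inhibitor. Compound 1 is the weakest of the three in this assay. The change chloro in place of fluoro on an aromatic carbon gives a 3.6-fold lower number from compound 1 to compound 2 (0.55 log units; beyond the scatter). The change methyl in place of hydrogen on a saturated ring carbon gives a 3.0-fold lower number from compound 1 to compound 3 (0.48 log units; beyond the scatter); the values of compound 2 and compound 3 lie within the scatter of each other, so no order between them is claimed.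

Compound 4 `CC1CN(c2cccc(Cl)c2)NC(=O)N1` is not yet measured. It differs from compound 3 by chloro in place of fluoro on an aromatic carbon, the same kind of change as that from compound 1 to compound 2; the two cores differ by methyl in place of hydrogen on a saturated ring carbon, so around the place the ring carbon is "meta to a group of 7 heavy atoms" in compound 1 but "meta to a group of 8 heavy atoms" in compound 3. A step like the earlier one is expected in this assay, a 3.2-fold lower number from compound 3 to compound 4 (0.50 log units; beyond the scatter), resting on compound 1 to compound 2 a 3.6-fold lower number from compound 1 to compound 2 (0.55 log units; beyond the scatter) and on compound 3 at 6300 nM. Among the measured compounds shown here, only one measured instance of the change exists, so this is a loose expectation. Compound 4 is estimated at 2000 nM, between 900 nM and 4500 nM.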

Compound 4, half-maximal inhibitory concentration: 2700 nM
Compound 4: the middle estimate sits 1.4-fold (0.13 log units) below what was measured; the measured number falls inside the stated range.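

In this assay, chloro in place of fluoro on an aromatic carbon also lowers the number on the methyl-bearing core, giving a 2.3-fold lower number from compound 3 to compound 4 (0.37 log units; beyond the scatter), and the two instances of this change do not separate: the same change on two cores in this assay, a 3.6-fold lower number (0.55 log units; beyond the scatter) from compound 1 to compound 2 and a 2.3-fold lower number (0.37 log units; beyond the scatter) from compound 3 to compound 4, 1.5-fold (0.19 log units) apart, within the scatter of two such steps. Methyl in place of hydrogen on a saturated ring carbon gives a 2.0-fold lower number from compound 2 to compound 4 (0.29 log units; within the scatter) on the chloro-bearing core, and its two instances do not separate either: the same change on two cores in this assay, a 3.0-fold lower number (0.48 log units; beyond the scatter) from compound 1 to compound 3 and a 2.0-fold lower number (0.29 log units; within the scatter) from compound 2 to compound 4, 1.5-fold (0.19 log units) apart, within the scatter of two such steps. Among the compounds shown here, the two changes therefore carry across these four compounds without a detectable dependence on the core, but this rests on only two instances of each change in one assay and shows nothing about other cores or why the values move.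

As far as these compounds go, it remains open whether bromo, methoxy or trifluoromethyl on the same aromatic carbon would extend the step seen from fluoro to chloro. Also open, from the compounds shown here alone, is how an ethyl group or a longer chain on the saturated ring carbon would compare with methyl.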